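Shifting the naphthalene attachment point in an amide series

The compounds below may be only part of what the source reports. "The series", "measured", "known", "first", "only" and "open" are said of these compounds alone.

In an assay on isolated protein for displacement of a labelled ligand from D(4) dopamine receptor (Homo sapiens) (on this read-out higher numbers stand for weaker inhibition and lower numbers for stronger inhibition), three compounds have been measured:
compound 1, `O=C(NC1CCN(Cc2cccc(C(F)(F)F)c2)CC1)c1cccc2ccccc12`, 119 nM
compound 2, `O=C(NC1CCN(Cc2ccc(C(F)(F)F)cc2)CC1)c1cccc2ccccc12`, 96 nM
compound 3, `Cc1ccc(CN2CCC(NC(=O)c3cccc4ccccc34)CC2)cc1`, 69 nM

Compound 2 stands second highest of these three numbers, with compound 1 nearest and compound 3 furthest, both within the scatter. Compound 4, `O=C(NC1CCN(Cc2ccc(C(F)(F)F)cc2)CC1)c1ccc2ccccc2c1`, differs from compound 2 by naphthalen-2-yl in place of naphthalen-1-yl on a carbonyl carbon. Among the measured compounds shown here, none of the measured steps touches this part of the molecule: a 1.2-fold lower number from compound 1 to compound 2 (0.09 log units; within the scatter), a 1.7-fold lower number from compound 1 to compound 3 (0.24 log units; within the scatter) and a 1.4-fold lower number from compound 2 to compound 3 (0.14 log units; within the scatter) all concern the group on the ring-bound amine side, and all lie within the scatter. For the measured compounds named here, no measured step therefore bears on the change to compound 4, and the direction of this assay cannot be read from the data. Compound 4 is expected near 150 nM, between 35 nM and 650 nM, which means an expected step of a 1.6-fold higher number from compound 2 to compound 4 (0.19 log units; within the scatter).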

Compound 4, inhibition constant: 84 nM
Estimate against measurement, compound 4: 1.8-fold (0.25 log units) above, and the stated range covers the measured number.
By their numbers in this assay, from the lowest: compounds 3, 4, 2 and 1 (each within the scatter of the next).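

In this assay, naphthalen-2-yl in place of naphthalen-1-yl on the carbonyl carbon gives a 1.1-fold lower number from compound 2 to compound 4 (0.06 log units; within the scatter). Among the compounds shown here, this is the first view of this part of the molecule, and with the 4-(trifluoromethyl)phenyl group held fixed, the two naphthalene attachments cannot be told apart. No available evidence bears on this result. From the compounds shown here alone, it remains open whether a simple phenyl or a quinolinyl group on the carbonyl carbon would keep the read-out in this range, and whether naphthalen-2-yl would give the same result alongside the 4-methylphenyl group of compound 3.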